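This account rests on a few compounds, and the source may have more. Where it says the series, first, only, none or still open, it means among the compounds named here.

Measured so far:
compound 1, `CCCCOc1nc(N)nc2[nH]cnc12` — 493000 nM
compound 2, `COC(COc1[nH]c(N)nc2ncnc1-2)(OC)c1ccccc1` — > 1000000 nM

Among the measured compounds shown here, compound 1 has the only number obtained in an assay on HT-29 cells for inhibition of Methylated-DNA--protein-cysteine methyltransferase (Homo sapiens); a higher number here means a weaker inhibitor, a lower number a stronger inhibitor. Compound 2 gives only a limit of the assay there, (the limit of > 1000000 nM in this assay, at which 1 of the 2 values shown sits). Compound 3, `Nc1nc(OCC2=CCCCC2)c2nc[nH]c2n1`, is not yet measured in this assay. It differs from compound 1 by cyclohex-1-en-1-yl in place of propyl on a saturated chain carbon bound to an oxygen on an aromatic ring. For the measured compounds named here, with no measured step between these compounds, no size can be read from the data; the author expects the change to strengthen inhibition by well more than the scatter, a 99-fold lower number from compound 1 to compound 3 (1.99 log units; beyond the scatter). Compound 3 is therefore estimated at 5000 nM, with a range from 500 nM to 50000 nM.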

Compound 3, half-maximal inhibitory concentration: 1600 nM
Beside the measured number, compound 3's estimate is 3.1-fold (0.49 log units) above it, within the range that was stated.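

In this assay, the place on a saturated chain carbon bound to an oxygen on an aromatic ring now has a measured size: cyclohex-1-en-1-yl in place of propyl gives a 310-fold lower number from compound 1 to compound 3 (2.49 log units; beyond the scatter). Inhibition at this place therefore depends strongly on the group it carries, and the ring with its double bond goes with a much lower number. Compound 2 still gives only a limit of the assay: the limit of > 1000000 nM in this assay, at which 1 of the 3 values shown sits.

On these data alone, whether the ring or the double bond carries the step stays open; a saturated cyclohexyl group in the same place would separate the two. As far as these compounds go, how a phenyl ring or a longer chain there would compare also stays open.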